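This account rests on a few compounds, and the source may have more. Where it says the series, first, only, none or still open, it means among the compounds named here.

In a functional assay on HCT-116 cells (Homo sapiens) for antiproliferative activity, read by MTT assay, with a stated time of 48 h (a higher number here means a weaker inhibitor, a lower number a stronger inhibitor), compound 1 (`Cc1c(C(=O)NCCS(C)(=O)=O)oc2ccc(N(Cc3ccc(Br)cc3)S(=O)(=O)c3ccc(Br)cc3)cc12`) gives > 40000 nM, which is a limit of the assay and not a number. Within the data shown here, compound 2 (`Cc1c(C(=O)NCC(O)CO)oc2ccc(N(Cc3ccc(Br)cc3)S(=O)(=O)c3ccc(Br)cc3)cc12`) gives 11500 nM, the only actual number so far. Compound 3 (`Cc1c(C(=O)N2CCCC(C)C2)oc2ccc(N(Cc3ccc(Br)cc3)S(=O)(=O)c3ccc(Br)cc3)cc12`) keeps the shared core and changes the group on the carbonyl carbon, with 3-methylpiperidin-1-yl in place of (2,3-dihydroxypropyl)amino on a carbonyl carbon. Among the measured compounds shown here, only one measured step bears on this part of the molecule, an at least 3.4-fold lower number from compound 1 to compound 2 (0.54 log units; beyond the scatter), where 1,2-dihydroxyethyl replaces (methylsulfonyl)methyl. It shows that a change in this side chain can move the result, but it swaps one open chain for another and gives no direction for a ring. The expected change is therefore a 1.3-fold lower number from compound 2 to compound 3 (0.11 log units; within the scatter), with no shift beyond the scatter expected in this assay, although the uncertainty is wide. For compound 3, the estimated value is 9000 nM, with an expected range from 2000 nM to 35000 nM.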

Compound 3, half-maximal inhibitory concentration: 28300 nM
Compound 3: middle estimate off by 3.1-fold (0.50 log units), on the low side, within the range that was stated.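

In this assay, the first ring at this position gives a 2.5-fold higher number from compound 2 to compound 3 (0.39 log units; beyond the scatter), so a ring on the carbonyl carbon does not preserve the result of the open (2,3-dihydroxypropyl)amino chain. With steps beyond the scatter to both other compounds, compound 2 is the strongest inhibitor of the three. Compound 1 can be compared only as a floor, an at least 1.4-fold lower number from compound 1 to compound 3 (0.15 log units; that floor lies within the scatter), because its value is a limit of the assay and not a number: the limit of > 40000 nM in this assay, at which 1 of the 3 values shown sits.

The step to 3-methylpiperidin-1-yl changes the chain, the hydrogen-bond donors and acceptors, and the ring with its methyl all at once, and the compounds shown do not separate these changes. Open questions include how an unsubstituted piperidin-1-yl, a morpholin-4-yl or a hydroxypiperidin-1-yl would behave here.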